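Carbamoyl for fluorophenyl in a pyrazole carboxylic acid series

The source may report more compounds than this note shows. Statements on the series, on what has been measured and on what is new or still open speak of the compounds shown alone.

Measured compounds:
compound 1, `Cc1n[nH]c(C(=O)O)c1Cc1cccc2ccccc12`, 59%
compound 2, `Cc1n[nH]c(C(=O)O)c1Cc1cccc(-c2ccccc2F)c1`, 22%
compound 3, `Cc1n[nH]c(C(=O)O)c1Cc1cccc(-c2ccc(C(N)=O)cc2)c1`, 60%

Three compounds sharing one core were tested in an assay on isolated protein for inhibition of 2-Hydroxyacid oxidase 2 (Homo sapiens), tested at 10 uM; on this read-out lower numbers stand for a weaker effect and higher numbers for a stronger effect at the one concentration tested. Compound 1 gives 59% and compound 3 gives 60%, two numbers that lie within the scatter of each other. Compound 2 stands lowest of the three in this assay with 22%; its gap to compound 1 and its gap to compound 3 are both beyond the scatter.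

Compound 4, `Cc1n[nH]c(C(=O)O)c1Cc1cccc(C(N)=O)c1`, has not yet been measured. It differs from compound 2 in one place: carbamoyl in place of 2-fluorophenyl on an aromatic carbon. No pair of measured compounds differs in just this way, so the size of the step cannot be read from the data shown. Because compound 3, which carries a carbamoyl on a larger group, gives 60%, a modest rise from the low position of compound 2 is expected, though a step within the scatter is also plausible, and the expected step is a number 13 percentage points higher from compound 2 to compound 4 (beyond the scatter). Compound 4 is expected to give about 35%, estimated between 10% and 65%.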

Compound 4, a percentage reported as inhibition, at one concentration (the size of the read-out at that concentration, not a potency): 8%
Beside the measured number, compound 4's estimate is 27 percentage points above it, and the stated range ends above it.
By their numbers in this assay, from the lowest: compound 4; then compound 2; then compounds 1 and 3 (each within the scatter of the next).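

In this assay, carbamoyl in place of 2-fluorophenyl on this aromatic carbon gives a number 14 percentage points lower from compound 2 to compound 4 (beyond the scatter), so exchanging the aromatic ring for this smaller group, with its hydrogen-bond donor and acceptor, does not lift the read-out here. Carbamoyl alone at this place is also not enough to reach the higher numbers in the series: compound 3, which holds its carbamoyl on an additional aromatic ring, gives 60%, whereas compound 4 gives 8%. No measurement shown here explains why the step runs in this direction.

The compounds shown leave open whether a carboxylic acid or an aminomethyl group on this aromatic carbon would behave like carbamoyl. They also leave open how an unsubstituted phenyl at this place would compare with 2-fluorophenyl.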